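A Pyrazole in Place of the Sulfamoylphenyl Arm

The source may report more compounds than this note shows. Statements on the series, on what has been measured and on what is new or still open speak of the compounds shown alone.

Measured compounds:
compound 1 `O=C(O)Cc1sc(C(c2ccc(F)cc2)c2ccc(F)cc2)nc1-c1cccc(F)c1`: 1.4 nM
compound 2 `N#Cc1cc(-c2nc(C(c3ccc(F)cc3)c3ccc(F)cc3)sc2CC(=O)O)ccc1F`: 57 nM
compound 3 `NS(=O)(=O)c1cccc(-c2nc(C(c3ccc(F)cc3)c3ccc(F)cc3)sc2CC(=O)O)c1`: 140 nM

In an in vitro assay on HEK385-7 cells for displacement of a labelled ligand from prostaglandin D2 receptor 2 (Homo sapiens) (a lower number here means a stronger inhibitor, a higher number a weaker inhibitor), compound 3 stands highest of the three numbers; the nearest is compound 2 (a 2.5-fold higher number from compound 2 to compound 3 (0.39 log units; beyond the scatter)), the furthest compound 1 (a 100-fold higher number from compound 1 to compound 3 (2.00 log units; beyond the scatter)). Compound 4 `O=C(O)Cc1sc(C(c2ccc(F)cc2)c2ccc(F)cc2)nc1-c1cn[nH]c1` differs from compound 3 in one place: 1H-pyrazol-4-yl in place of 3-sulfamoylphenyl on an aromatic carbon.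

Among the measured compounds shown here, two measured steps bear on this position. Both replacements of the group on the shared core moved the numbers upward: a 41-fold higher number from compound 1 to compound 2 (1.61 log units; beyond the scatter) and a 100-fold higher number from compound 1 to compound 3 (2.00 log units; beyond the scatter). Among the groups tried so far the plain 3-fluorophenyl of compound 1 gave the lowest number, and every other group gave a higher one. No aromatic group other than a substituted phenyl has been measured here, so the direction of the move to 1H-pyrazol-4-yl rests on little. Compound 4 is therefore expected to fall between the extremes seen, with an estimate of 50 nM in this assay, ranging from 5 nM to 500 nM. This estimate implies a step of a 2.8-fold lower number from compound 3 to compound 4 (0.45 log units; beyond the scatter), expected but uncertain.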

Compound 4, half-maximal inhibitory concentration: 16 nM
Compound 4: the middle estimate sits 3.1-fold (0.49 log units) above what was measured, within the range that was stated.
By their numbers in this assay, from the lowest: compound 1; then compound 4; then compound 2; then compound 3.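

In this assay, among the compounds shown here, the 1H-pyrazol-4-yl is the first replacement at this position to lower the number, with an 8.8-fold lower number from compound 3 to compound 4 (0.94 log units; beyond the scatter) and a 3.6-fold lower number from compound 2 to compound 4 (0.55 log units; beyond the scatter), so on this core a group need not be a substituted phenyl to improve on the 3-sulfamoylphenyl and the 3-cyano-4-fluorophenyl. It does not match the plain 3-fluorophenyl, however: an 11-fold higher number from compound 1 to compound 4 (1.06 log units; beyond the scatter) remains, and compound 1 keeps the lowest number of the four. No supporting measurement is available to explain these differences.

The compounds shown leave open whether the number of compound 4 would hold, fall or rise with a methyl on the pyrazole ring nitrogen, or with a pyridin-3-yl in place of the pyrazole. They also leave open whether an unsubstituted phenyl at this position would give a lower number than the 3-fluorophenyl.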